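Back from an azetidinyl amide to a plain dialkyl amide

This account rests on a few compounds, and the source may have more. Where it says the series, first, only, none or still open, it means among the compounds named here.

Among the measured compounds shown here, compound 2 `CCN(CC)S(=O)(=O)c1ccc(S(=O)(=O)N2CCC[C@@H](C(=O)NC3CN(C(=O)C4CC4)C3)C2)cc1` gives 3100 nM in a functional assay on MIA PaCa-2 cells (Homo sapiens) for inhibition, read by MTT assay, with a stated time of 3 days (on this read-out higher numbers stand for weaker inhibition and lower numbers for stronger inhibition), the highest of the two numbers measured so far; its nearest neighbour, compound 1 `CCN(CC)S(=O)(=O)c1ccc(S(=O)(=O)N2CCC[C@@H](C(=O)N(C)C(C)C)C2)cc1`, gives 1400 nM. These two differ at one place, and the step of a 2.2-fold higher number from compound 1 to compound 2 (0.35 log units; beyond the scatter) came from putting the ring-bearing group in place of a small dialkylamino group on the carbonyl carbon. Compound 3 `CCN(CC)C(=O)[C@@H]1CCCN(S(=O)(=O)c2ccc(S(=O)(=O)N(CC)CC)cc2)C1` carries the change (diethylamino in place of (1-(cyclopropylcarbonyl)azetidin-3-yl)amino on a carbonyl carbon). Diethylamino, like isopropyl(methyl)amino, is a dialkylamino group with no ring and no hydrogen-bond donor, and this change largely undoes the one measured step. For the measured compounds named here, that step is the only evidence bearing on compound 3, and a modest fall in the number, close in size to it, is expected in this assay. Compound 3 is estimated at 1500 nM, with a range of 600 nM to 4000 nM, an expected step of a 2.1-fold lower number from compound 2 to compound 3 (0.32 log units; beyond the scatter).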

Compound 3, half-maximal inhibitory concentration: 700 nM
Compound 3: middle estimate off by 2.1-fold (0.33 log units), on the high side; low and high end bracket the measured number.
By their numbers in this assay, from the lowest: compounds 3 and 1 (each within the scatter of the next); then compound 2.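

In this assay, diethylamino in place of (1-(cyclopropylcarbonyl)azetidin-3-yl)amino on the carbonyl carbon gives a 4.4-fold lower number from compound 2 to compound 3 (0.65 log units; beyond the scatter), so two different dialkylamino groups, each with no ring, now both read lower than the ring-bearing group of compound 2. The two dialkylamino groups themselves cannot be told apart, with a 2.0-fold lower number from compound 1 to compound 3 (0.30 log units; within the scatter), so at this position the swap of isopropyl(methyl)amino for diethylamino shows no real difference. Nothing measured here explains why the numbers fall as they do.

The three-membered ring, the four-membered ring and the hydrogen-bond donor all leave together, so the compounds shown cannot say which of them matters. They also leave open how a longer chain, such as dipropylamino, or a carboxylic acid on that chain would read at this carbonyl carbon.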